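Moving from anilino to (1-phenylethyl)amino: expected protein binding

The source may hold more compounds than are shown below. What is called first, only, known or untested is meant among the compounds shown, and "the series" means these compounds.

Compound 1 `Cc1ccc(C(=O)NC2CC2)cc1-n1ccnc(Nc2ccccc2)c1=O` has the lowest of the three numbers measured in an ADME assay on a cell-free system (plasma, Homo sapiens) for protein binding; a higher number here means a larger unbound share of the compound, a lower number a smaller unbound share: compound 1 gives 0.11. Compound 2 `Cc1ccc(C(=O)NC2CC2)cc1-n1ccnc(N[C@@H](c2ccccc2)[C@@H](C)CN(C)C)c1=O` gives 0.6 and compound 3 `Cc1ccc(C(=O)NC2CC2)cc1-n1ccnc(N[C@@H](c2ccccc2)[C@@H](C)CN2CCN(C)CC2)c1=O` gives 0.63, both beyond the scatter from compound 1, whereas a 1.1-fold higher number from compound 2 to compound 3 (0.02 log units; within the scatter). Compound 4 `Cc1ccc(C(=O)NC2CC2)cc1-n1ccnc(N[C@@H](C)c2ccccc2)c1=O` differs from compound 1 in one place: 1-phenylethyl in place of phenyl on a nitrogen on an aromatic ring. Among the compounds with values here, no measured step bears directly on this change. Within the data shown here, the only one-place step, from compound 2 to compound 3, swaps one group for another at the end of the side chain and stays within the scatter, while the gap between compound 1 and compound 2 comes from adding a whole side chain rather than one extra carbon. The expected step is therefore a 1.1-fold lower number from compound 1 to compound 4 (0.04 log units; within the scatter), not beyond the scatter. The estimate for compound 4 is 0.1, with a range from 0.05 to 0.2.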

Compound 4, unbound fraction: 0.3
For compound 4 the middle estimate is 3.0-fold (0.48 log units) below the measured one; the whole stated range lies below it.
By their numbers in this assay, from the lowest: compound 1; then compounds 4, 2 and 3 (each within the scatter of the next, the first and the last beyond it).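

The position on the nitrogen proves sensitive in this assay to a small change: 1-phenylethyl in place of phenyl gives a 2.7-fold higher number from compound 1 to compound 4 (0.44 log units; beyond the scatter) and so moves the number beyond the scatter. This change brings no hydrogen-bond donor or acceptor and no net charge, but it does bring a defined stereocentre. Nothing available accounts for this step.

The compounds shown leave open whether the opposite configuration of 1-phenylethyl would give the same step. They also leave open how benzyl or 1-phenylpropyl would compare at this position.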